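From bromo to fluoro: what compound 4 may show

The source may hold more compounds than are shown below. What is called first, only, known or untested is meant among the compounds shown, and "the series" means these compounds.

Measured in a functional assay on SK-MEL-28 cells (Homo sapiens) for cytotoxicity, read by MTT assay; a higher number here means a weaker inhibitor, a lower number a stronger inhibitor:
Compound 1 `O=S(=O)(NCCCNc1nccc(-c2c(-c3cccc(F)c3)nc3sccn23)n1)c1ccc(Br)cc1`: 9400 nM.
Compound 2 `O=S(=O)(NCCCNc1nccc(-c2c(-c3cccc(F)c3)nc3sccn23)n1)c1ccc(F)cc1`: > 20000 nM, which is a limit.
Compound 3 `O=S(=O)(NCCNc1nccc(-c2c(-c3cccc(F)c3)nc3sccn23)n1)c1ccc(Br)cc1`: 13500 nM.

Compound 3 gives 13500 nM and compound 1 gives 9400 nM. Among the measured compounds shown here, these are the only two true numbers in the set, and they are not separated: the step is a 1.4-fold higher number from compound 1 to compound 3 (0.16 log units; within the scatter). Compound 2 has only a limit, not a number.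

Compound 4 `O=S(=O)(NCCNc1nccc(-c2c(-c3cccc(F)c3)nc3sccn23)n1)c1ccc(F)cc1` is reached by one change, fluoro in place of bromo on an aromatic carbon, para to a large group. The same exchange has been measured once, on the longer chain, as an at least 2.1-fold higher number from compound 1 to compound 2 (0.32 log units; beyond the scatter). That size is only a floor, as the second value is a limit. A step of similar size towards a higher number, beyond the scatter, is therefore expected in this assay. Such a step could well take the reading to the ceiling of the assay: the limit of > 20000 nM in this assay, at which 1 of the 3 values shown sits. The expected change is a 2.2-fold higher number from compound 3 to compound 4 (0.35 log units; beyond the scatter). For compound 4 the estimated value is 30000 nM, with an expected range from 16000 nM to 60000 nM.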

Compound 4, half-maximal inhibitory concentration: 9450 nM
For compound 4 the middle estimate is 3.2-fold (0.50 log units) above the measured one; the measured number lies below the stated range.
By their numbers in this assay, from the lowest: compounds 1, 4 and 3 (each within the scatter of the next). At a limit, above all of these: compound 2.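

On the shorter chain, the change from 4-bromophenyl to 4-fluorophenyl leaves the two compounds unseparated in this assay, a 1.4-fold lower number from compound 3 to compound 4 (0.15 log units; within the scatter), so this exchange does not read the same on the two chains: the same change on two cores in this assay, an at least 2.1-fold higher number (0.32 log units; beyond the scatter) from compound 1 to compound 2 and a 1.4-fold lower number (0.15 log units; within the scatter) from compound 3 to compound 4, at least 3.0-fold (0.48 log units) apart, beyond the scatter of two such steps

With fluoro in place, shortening the chain gives an at least 2.1-fold lower number from compound 2 to compound 4 (0.32 log units; beyond the scatter), while the step that changes both halogen and chain, a 1.0-fold higher number from compound 1 to compound 4 (0.00 log units; within the scatter), stays within the scatter. Compound 2 carries only a limit, > 20000 nM, so the floor of the step from it is all that can be read.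

On these data alone, how far the two fluoro compounds truly lie apart stays open, and so does whether the difference between the chains holds for other halogens. Nor do the compounds shown tell how chloro, methoxy or a longer chain would read in this assay.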